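Swapping the amide tail from a chain to a furan-2-yl ring

The compounds below may be only part of what the source reports. "The series", "measured", "known", "first", "only" and "open" are said of these compounds alone.

Measured in a functional assay on HepG2 cells (Homo sapiens) for inhibition, read by MTT assay, with a stated time of 48 h; on this read-out higher numbers stand for weaker inhibition and lower numbers for stronger inhibition:
Compound 1 `O=C(CC1CCOCC1)Nc1ccc(N2CCN(c3ccc(OC[C@@H]4CO[C@@](Cn5cncn5)(c5ccc(Cl)cc5Cl)O4)cc3)CC2)cc1` gives 21100 nM
Compound 2 `O=C(CCCc1ccccc1)Nc1ccc(N2CCN(c3ccc(OC[C@@H]4CO[C@@](Cn5cncn5)(c5ccc(Cl)cc5Cl)O4)cc3)CC2)cc1` gives 10800 nM

Compound 2 sits at one end of these two numbers, but the step of a 2.0-fold lower number from compound 1 to compound 2 (0.29 log units; within the scatter) is within the scatter, so compound 1 and compound 2 cannot be told apart on this evidence.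

Compound 3 `O=C(Nc1ccc(N2CCN(c3ccc(OC[C@@H]4CO[C@@](Cn5cncn5)(c5ccc(Cl)cc5Cl)O4)cc3)CC2)cc1)c1ccco1` differs from compound 2 only at the amide tail: furan-2-yl in place of 3-phenylpropyl on a carbonyl carbon. For the measured compounds named here, the only measured step that bears on this region is a 2.0-fold lower number from compound 1 to compound 2 (0.29 log units; within the scatter), where the group on the chain bound to the carbonyl carbon was exchanged, and that step stayed within the scatter. Here the whole 3-phenylpropyl chain is replaced by a furan-2-yl ring, a bigger change than the measured step, but with only one step to go on, there is no basis to expect movement beyond the scatter in either direction in this assay.

Compound 3 is therefore expected to give about 13000 nM, with a range from 4000 nM to 40000 nM. The expected step of a 1.2-fold higher number from compound 2 to compound 3 (0.08 log units; within the scatter) remains within the scatter.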

Compound 3, half-maximal inhibitory concentration: 22300 nM
Beside the measured number, compound 3's estimate is 1.7-fold (0.23 log units) below it, within the range that was stated.
By their numbers in this assay, from the lowest: compounds 2, 1 and 3 (each within the scatter of the next, the first and the last beyond it).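

In this assay, the amide tail now gives its first step beyond the scatter (a 2.1-fold higher number from compound 2 to compound 3 (0.31 log units; beyond the scatter)), a modest move when furan-2-yl replaces 3-phenylpropyl on the carbonyl carbon. Exchanging (oxan-4-yl)methyl for the same ring gives a step within the scatter (a 1.1-fold higher number from compound 1 to compound 3 (0.02 log units; within the scatter)), so these two tails cannot be told apart here, and the only separation among the three compounds is the small one between the 3-phenylpropyl and furan-2-yl tails. Nothing shown here gives a measured reason for that separation.

The exchange from 3-phenylpropyl to furan-2-yl removes the chain and changes the ring in a single move, so the compounds shown cannot say which part of the change goes with the step. From the compounds shown here alone, it also remains open how far this position can move the number at all, a question that a phenyl ring placed directly on the carbonyl carbon, or a tail ending in an amine or a carboxylic acid, could help to answer.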